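The compounds below may be only part of what the source reports. "The series", "measured", "known", "first", "only" and "open" are said of these compounds alone.

Measured compounds:
compound 1, `Clc1ccc(-c2cc(-c3ccc(Cl)cc3)[nH]n2)cc1`, 6030 nM
compound 2, `Cc1ccc(-c2cc(-c3ccccc3)[nH]n2)cc1`, 1 nM

In an assay on mitochondria from brain for inhibition of Amine oxidase [flavin-containing] B (Bos taurus), read by fluorescence (a lower number here means a stronger inhibitor, a higher number a weaker inhibitor), compound 2 gives 1 nM, the lowest of the two numbers recorded. Its nearest neighbour is compound 1, which in this assay gives 6030 nM, a gap far beyond the usual scatter. For the measured compounds named here, the two compounds differ in more than one place, so no single step between them can be isolated.

Compound 3, `Cc1ccc(-c2cc(-c3ccc(Cl)cc3)[nH]n2)cc1`, has not yet been measured. It is reached from compound 2 by one change: chloro in place of hydrogen on an aromatic carbon, on an aromatic carbon of a six-membered aromatic ring of carbon only, para to a large group. Going by the values given here, no measured pair shows this exact step, so its size can only be guessed. Since compound 1, which carries chloro on both outer rings, sits far above compound 2 in this assay, a move toward compound 1 seems more likely than the reverse, though a result within the scatter cannot be excluded.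

Compound 3 is therefore estimated at 20 nM, within 1 nM to 400 nM. This estimate means a step of a 20-fold higher number from compound 2 to compound 3 (1.30 log units; beyond the scatter), with wide uncertainty.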

Compound 3, half-maximal inhibitory concentration: 8.91 nM
Compound 3: middle estimate off by 2.2-fold (0.35 log units), on the high side; low and high end bracket the measured number.
By their numbers in this assay, from the lowest: compound 2; then compound 3; then compound 1.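

In this assay, for the compounds shown here, chloro in place of hydrogen on an aromatic carbon, para to a large group, gives an 8.9-fold higher number from compound 2 to compound 3 (0.95 log units; beyond the scatter) and so shows for the first time, as a single change, that this position responds to the substitution, though the step remains modest. Methyl in place of chloro on an aromatic carbon of the other outer ring gives a 680-fold lower number from compound 1 to compound 3 (2.83 log units; beyond the scatter) and is the larger of the two steps, so the two single changes, which the earlier pair could not separate, are not equal in size in this series. Nothing measured here bears on why either step has the size it has.

The compounds shown leave open whether the chloro step is specific to chloro, since only hydrogen and chloro are seen at this position, and a fluoro, a methoxy or an amine there could give a quite different number. They also leave open whether the chloro step keeps its size when the other outer ring carries something other than methyl, and whether the nitrogen-bearing core tolerates any change, since it stays the same throughout.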